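Working notes: compound 4, benzyl ether at the aryl oxygen

The source may report more compounds than this note shows. Statements on the series, on what has been measured and on what is new or still open speak of the compounds shown alone.

Measured compounds:
compound 1 `C=CCOc1c(C)c(C)c2c(c1C)CCC(C)(COc1ccc(/C=C3\SC(=O)NC3=O)cc1OCC)O2`
compound 2 `Cc1c(C)c2c(c(C)c1OC(=O)CCC(=O)O)CCC(C)(COc1ccc(/C=C3\SC(=O)NC3=O)cc1)O2`
compound 3 `CCOc1cc(/C=C2\SC(=O)NC2=O)ccc1OCC1(C)CCc2c(C)c(OCC=C(C)C)c(C)c(C)c2O1`

In a functional assay on MCF7 cells (Homo sapiens), tested at 2.5 uM (a higher number here means a weaker effect of the compound at the concentration tested, a lower number a stronger effect), compound 1 gives 107%, compound 2 gives 115% and compound 3 gives 107%. None of the three shows an effect at the concentration tested. Compound 2 has the highest of the three numbers, but its gap to compound 1 and its gap to compound 3 are each within the scatter, so no order among them can be read.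

The compound not yet measured is compound 4 `Cc1c(C)c2c(c(C)c1OCc1ccccc1)CCC(C)(COc1ccc(/C=C3\SC(=O)NC3=O)cc1)O2`. Relative to compound 2 the change is benzyl in place of (2-carboxyethyl)carbonyl on an oxygen on an aromatic ring.

Among the compounds with values here, only one measured step is available: no change at the digits printed from compound 1 to compound 3 (within the scatter). It concerns a different group at the same oxygen position and shows nothing beyond the scatter. Within the data shown here, there is no measured step that swaps an acyl group for a benzyl group at this oxygen, so the one step bears on the case only loosely. Since all three measured numbers sit in the region of no effect in this assay, the expectation for compound 4 is a step of a number 7 percentage points lower from compound 2 to compound 4 (within the scatter), none beyond the scatter. Compound 4 is therefore estimated at 108%, with a range of 96% to 120%.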

Compound 4, a percentage reported as activity, at one concentration (the size of the read-out at that concentration, not a potency): 85%
Compound 4: the middle estimate sits 23 percentage points above what was measured, and the stated range ends above it.
By their numbers in this assay, from the lowest: compound 4; then compounds 1, 3 and 2 (each within the scatter of the next).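

In this assay, within the data shown here, benzyl in place of (2-carboxyethyl)carbonyl on an oxygen on an aromatic ring gives a number 30 percentage points lower from compound 2 to compound 4 (beyond the scatter), whereas the only earlier step, no change at the digits printed from compound 1 to compound 3 (within the scatter), showed no shift at this oxygen. The position is therefore not silent: the read-out at the tested concentration can respond to the group placed here, at least for this exchange of an acyl chain for an arylmethyl group. The exchange changes several things at once, as the leaving group brings a hydrogen-bond donor and no ring and the entering group brings an aromatic ring of carbon only, and no measurement on hand says which of these matters.

Acetyl would test an acyl group lacking the carboxylic acid, and cyclohexylmethyl would test a ring that is not aromatic, so either could help separate these two features. From the compounds shown here alone, it also remains open whether benzyl at this oxygen gives a similar step in the presence of the ethoxy group carried by compound 1 and compound 3, and a single-concentration read-out gives no potency for compound 4.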